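A few compounds are considered here, and "the series" means these few. Any claim that something is new, unique, unknown or untested is made for them only; others in the source may bear on it.

Measured compounds:
compound 1, `N#Cc1ccc(-c2nc(C(c3ccc(F)cc3)c3ccc(F)cc3)sc2CC(=O)O)cc1`, 1500 nM
compound 2, `O=C(O)Cc1sc(C(c2ccc(F)cc2)c2ccc(F)cc2)nc1-c1ccco1`, 140 nM
compound 3, `O=C(O)Cc1sc(C(c2ccc(F)cc2)c2ccc(F)cc2)nc1-c1ccnc(Cl)c1`, 39 nM

All three share one core and differ only in the aromatic group attached to it; they were tested in an in vitro functional assay on HEK285-7 cells for antagonist activity at prostaglandin D2 receptor 2 (Homo sapiens), read by BRET and beta-arrestin recruitment; on this read-out lower numbers stand for stronger inhibition and higher numbers for weaker inhibition. Compound 3 stands lowest of the three numbers: its step from compound 2 is a 3.6-fold lower number from compound 2 to compound 3 (0.56 log units; beyond the scatter), and its step from compound 1 is a 38-fold lower number from compound 1 to compound 3 (1.59 log units; beyond the scatter). The step of an 11-fold lower number from compound 1 to compound 2 (1.03 log units; beyond the scatter) shows that the other two replacements of the 4-cyanophenyl group also lowered the number.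

Compound 4, `Nc1cc(-c2nc(C(c3ccc(F)cc3)c3ccc(F)cc3)sc2CC(=O)O)cc(F)n1`, has not been measured. It differs from compound 3 in one place: 2-amino-6-fluoropyridin-4-yl in place of 2-chloropyridin-4-yl on an aromatic carbon. Among the measured compounds shown here, no measured step exchanges one pyridinyl group for another, so the steps at hand bear on it only indirectly. They show that the two groups with a ring nitrogen or oxygen, in compound 2 and compound 3, gave lower numbers than the 4-cyanophenyl group of compound 1, and that moving between them changed the number by a modest amount. The new group keeps the pyridinyl ring of compound 3, so compound 4 is expected to give a number close to that of compound 3, the estimated step being a 1.1-fold lower number from compound 3 to compound 4 (0.05 log units; within the scatter). In this assay compound 4 is estimated at 35 nM, within a range from 8 nM to 150 nM.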

Compound 4, half-maximal inhibitory concentration: 1400 nM
Beside the measured number, compound 4's estimate is 40-fold (1.60 log units) below it, outside the stated range (above it).
By their numbers in this assay, from the lowest: compound 3; then compound 2; then compounds 4 and 1 (each within the scatter of the next).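

In this assay, among the compounds shown here, the pyridinyl ring alone does not carry the low number at this aromatic carbon of the shared core: exchanging 2-chloropyridin-4-yl for 2-amino-6-fluoropyridin-4-yl gives a 36-fold higher number from compound 3 to compound 4 (1.56 log units; beyond the scatter) and is the largest change yet seen between two pyridinyl-bearing compounds, a comparison the earlier compounds could not offer. The new group also goes against the earlier pattern in which replacing 4-cyanophenyl lowered the number, with a 10-fold higher number from compound 2 to compound 4 (1.00 log units; beyond the scatter) and with a 1.1-fold lower number from compound 1 to compound 4 (0.03 log units; within the scatter) so that 2-amino-6-fluoropyridin-4-yl and 4-cyanophenyl cannot be told apart on this read-out. Nothing at hand gives a reason for this large step.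

Which part of the new group goes with the step stays open, as the amine and the fluorine enter together and the chlorine leaves at the same time; a 2-aminopyridin-4-yl group and a 2-fluoropyridin-4-yl group would separate them. Also open, going by these compounds, is whether a 2-methylpyridin-4-yl or a 2-methoxypyridin-4-yl group would stay close to compound 3 or close to compound 4.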